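Sulfur-linked fluorophenyl chain replacing a methoxyphenyl ether

The compounds below may be only part of what the source reports. "The series", "measured", "known", "first", "only" and "open" are said of these compounds alone.

Compound 1 `COc1ccc(CCOc2ccc(-c3c(C)nc(C)c([C@H](OC(C)(C)C)C(=O)O)c3N3CCC(C)(C)CC3)cc2)cc1` is the reference point. In an ADME assay on microsomes from liver (Homo sapiens) for metabolic stability, read by LC-MS, tested at 0.5 uM (on this read-out higher numbers stand for a longer-lived compound and lower numbers for a shorter-lived compound), compound 1 gives > 2 h, which is a limit of the assay rather than a number. Compound 2 `Cc1nc(C)c([C@H](OC(C)(C)C)C(=O)O)c(N2CCC(C)(C)CC2)c1-c1ccc(OCCc2ccc(F)cc2F)cc1` gives 1.08 h in this assay. Compound 3 `Cc1nc(C)c([C@H](OC(C)(C)C)C(=O)O)c(N2CCC(C)(C)CC2)c1-c1ccc(CCCc2ccc(F)cc2)cc1` gives > 2 h in this assay, again a limit. The boundary concerned is the limit of > 2 h in this assay, at which 2 of the 3 values shown sit.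

Compound 4 `Cc1nc(C)c([C@H](OC(C)(C)C)C(=O)O)c(N2CCC(C)(C)CC2)c1-c1ccc(SCCc2ccc(F)cc2)cc1` has not been measured; it differs from compound 1 by (2-(4-fluorophenyl)ethyl)sulfanyl in place of 2-(4-methoxyphenyl)ethoxy on an aromatic carbon. Going by the values given here, two measured steps concern the same side chain: an at least 1.8-fold lower number from compound 1 to compound 2 (0.26 log units; that floor lies within the scatter) and an at least 1.8-fold higher number from compound 2 to compound 3 (0.26 log units; that floor lies within the scatter), while a step that the two limits leave unreadable from compound 1 to compound 3. Compound 2 carries a 2,4-difluorophenyl on an oxygen-linked chain and compound 3 a 4-fluorophenyl on an all-carbon chain; compound 4 carries a 4-fluorophenyl on a sulfur-linked chain, which matches neither exactly. The step expected for compound 4 is therefore an at least 1.1-fold lower number from compound 1 to compound 4 (0.04 log units; that floor lies within the scatter), small and not clearly beyond the scatter. Compound 4 is expected to reach 1.8 h in this assay, within a range from 0.8 h to 4 h.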

Compound 4, half-life: > 2 h
Compound 4 ended at the assay's limit; the forecaster's own chance of this, stated with the estimate: 40%; at least 1.1-fold (0.04 log units) between middle value and limit.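

In this assay, compound 4 ends at a limit of the assay, so a sulfur-linked chain carrying 4-fluorophenyl joins the oxygen-linked and all-carbon chains that reach this limit at this aromatic carbon, para to a large group. Going by these compounds alone, the one readable step is an at least 1.8-fold higher number from compound 2 to compound 4 (0.26 log units; that floor lies within the scatter) and it changes the linking atom and the fluorine pattern together, so it singles out neither. The steps to compound 4 from compound 1 and from compound 3 cannot be read because both ends of each sit at the same boundary: the limit of > 2 h in this assay, at which 3 of the 4 values shown sit.

On these data alone, how long compound 1, compound 3 and compound 4 actually last remains unknown. As far as these compounds go, it is also open whether a sulfonyl in place of the sulfur, an amine link or a longer chain would reach the same limit.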